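Swapping One Ring Substituent in a Cytotoxic Series

The compounds below may be only part of what the source reports. "The series", "measured", "known", "first", "only" and "open" are said of these compounds alone.

Measured so far:
compound 1 `CSc1ccc(C2=C(c3ccc(F)c(F)c3)C(=O)N3CCCC3C2)cc1` gives 300 nM
compound 2 `CSc1ccc(C2=C(c3ccc(F)c(C)c3)C(=O)N3CCCC3C2)cc1` gives 800 nM
compound 3 `COc1ccc(C2=C(c3ccc(SC)cc3)CC3CCCN3C2=O)cc1` gives 4000 nM

In a functional assay on M14 cells (Homo sapiens) for cytotoxicity (on this read-out lower numbers stand for stronger inhibition of growth and higher numbers for weaker inhibition of growth), compound 3 has the highest of the three numbers at 4000 nM and so shows the weakest growth inhibition here. Compound 4 `CSc1ccc(C2=C(c3ccc(SC)cc3)C(=O)N3CCCC3C2)cc1` has not yet been measured. It differs from compound 3 in one place, with methylsulfanyl in place of methoxy on an aromatic carbon so that 4-methoxyphenyl becomes 4-(methylsulfanyl)phenyl.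

Two measured steps involve this same ring. Putting 4-methoxyphenyl in place of 3,4-difluorophenyl gave a 13-fold higher number from compound 1 to compound 3 (1.12 log units; beyond the scatter) as a large step, and putting it in place of 4-fluoro-3-methylphenyl gave a 5.0-fold higher number from compound 2 to compound 3 (0.70 log units; beyond the scatter) as a modest one. A smaller edit on that ring also registered, with a 2.7-fold higher number from compound 1 to compound 2 (0.43 log units; beyond the scatter) as a modest step. So this ring clearly matters, and 4-methoxyphenyl is the poorest of the three rings tested. However, no measured compound shows the methylsulfanyl group there, so the direction remains an expectation.

A modest move towards a lower number is expected. The expected step is a 2.7-fold lower number from compound 3 to compound 4 (0.43 log units; beyond the scatter) on this estimate. Compound 4 is estimated at 1500 nM with an expected range from 400 nM to 5000 nM in this assay here.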

Compound 4, concentration for 50% growth inhibition: 5000 nM
Beside the measured number, compound 4's estimate is 3.3-fold (0.52 log units) below it, and the stated range covers the measured number.
By their numbers in this assay, from the lowest: compound 1; then compound 2; then compounds 3 and 4 (each within the scatter of the next).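

In this assay, within the data shown here, replacing methoxy with methylsulfanyl gives a 1.3-fold higher number from compound 3 to compound 4 (0.10 log units; within the scatter), so exchanging one oxygen for one sulfur at this spot leaves the growth-inhibition reading indistinguishable, something the earlier compounds could not reveal. Compound 4 also sits well apart from the two fluorinated compounds, with a 6.3-fold higher number from compound 2 to compound 4 (0.80 log units; beyond the scatter) and a 17-fold higher number from compound 1 to compound 4 (1.22 log units; beyond the scatter), so among these four compounds, both rings bearing fluoro give lower numbers than both rings bearing only methoxy or methylsulfanyl, and none of the four goes against this pattern. No supporting evidence is available to explain this difference between the rings.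

On these data alone, it remains open whether an amine or a carboxylic acid on the same aromatic carbon would read like methoxy and methylsulfanyl or like the fluoro-bearing rings. A longer chain such as butoxy could also show whether the similarity of these two small groups persists as the group grows, and a lone fluoro on that carbon could show how much of the gap comes from the fluoro itself.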